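Replacing a Spirocyclic Amide with a Fluorinated Aromatic Amide

The source may hold more compounds than are shown below. What is called first, only, known or untested is meant among the compounds shown, and "the series" means these compounds.

Measured compounds:
Compound 1, `O=C(C1CCC2(CCC2)CC1)N1CC(c2nc(-c3cccc(Cl)c3)no2)C1`: 1100 nM
Compound 2, `O=S(=O)(c1ccc(Cl)cc1)N1CC(c2nc(-c3cccc(Cl)c3)no2)C1`: > 10000 nM
Compound 3, `O=C([C@H]1CC2CCC1C2)N1CC(c2nc(-c3cccc(F)c3)no2)C1`: 72 nM

Three compounds share the same core and were tested in an assay on HEK293 cells for positive allosteric modulation of metabotropic glutamate receptor 5 (Homo sapiens), read by FLIPR; a lower number here means that less compound is needed, a higher number that more compound is needed for the effect. Compound 1 gives 1100 nM, the higher of the two numbers reported. Compound 3 gives 72 nM, a gap to compound 1 that lies beyond the scatter. For compound 2 the assay reports only a limit, > 10000 nM, and this is the limit of > 10000 nM in this assay, at which 1 of the 3 values shown sits.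

Compound 4, `O=C(c1ccc(F)cc1)N1CC(c2nc(-c3cccc(Cl)c3)no2)C1`, has not yet been measured in this assay. It differs from compound 1 in one place: a group of 7 heavy atoms (6 carbon, 1 fluorine; one six-membered aromatic ring of carbon only) in place of a group of 9 heavy atoms (9 carbon; one four-membered non-aromatic ring of carbon only, one six-membered non-aromatic ring of carbon only), on a carbonyl carbon. Among the compounds with values here, no pair of measured compounds differing in exactly one place is available, so the direction of this step cannot be read from a measured step. Compound 3 shows that a non-aromatic bicyclic amide can give a low number, while compound 1 shows a higher one with its spirocyclic amide; what an aromatic amide does in this position is not shown by any measured compound.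

The number for compound 4 is therefore expected near that of compound 1, with wide uncertainty: the estimate for compound 4 is 900 nM, between 150 nM and 6000 nM. This estimate implies a step from compound 1 to compound 4 of a 1.2-fold lower number from compound 1 to compound 4 (0.09 log units; within the scatter), which is expected to stay within the scatter.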

Compound 4, half-maximal effective concentration: > 10000 nM
Compound 4 ended at the assay's limit; the forecaster's own chance of this, stated with the estimate: 15%; middle value at least 11-fold (1.04 log units) away from the limit.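

In this assay, putting 4-fluorophenyl in place of the non-aromatic group with its four-membered and six-membered carbon rings, on the carbonyl carbon, gives an at least 9.0-fold higher number from compound 1 to compound 4 (0.95 log units; beyond the scatter). Within the data shown here, this is the first step read at this position, and it shows that the number here can change beyond the scatter when only the group on the carbonyl carbon is exchanged, and that an aromatic amide of this kind does not hold the number of the non-aromatic one. For compound 4 the value > 10000 nM is a limit of the assay and not a number, and with it the limit is now reached by a further compound: the limit of > 10000 nM in this assay, at which 2 of the 4 values shown sit.

What a plain phenyl, a pyridine or a cyclohexyl group would give on this carbonyl carbon remains open, so the compounds shown do not separate the effect of the aromatic ring from that of its fluorine. Going by these compounds, this is also a single step on the core of compound 1, and whether it would hold with other groups elsewhere on that core is equally open.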